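This account rests on a few compounds, and the source may have more. Where it says the series, first, only, none or still open, it means among the compounds named here.

The measured compounds:
Compound 1 `Cc1ncnc2c1c(-c1cccs1)cn2[C@@H]1O[C@H](CO)[C@@H](O)[C@H]1O`, which in a functional assay on HCT-116 cells (Homo sapiens), read by MTT assay, with a stated time of 72 h (a lower number here means a stronger inhibitor, a higher number a weaker inhibitor), gives > 20000 nM, a limit of the assay rather than a number.
Compound 2 `CNc1ncnc2c1c(-c1cccs1)cn2[C@@H]1O[C@H](CO)[C@@H](O)[C@H]1O`, which in this assay gives > 20000 nM, also only a limit.
Compound 3 `CNc1ncnc2c1c(-c1ccsc1)cn2[C@@H]1O[C@H](CO)[C@@H](O)[C@H]1O`, which in this assay gives > 20000 nM, again only a limit.

All three values sit at the limit of > 20000 nM in this assay, at which 3 of the 3 values shown sit, so the change from compound 2 to compound 1, (methyl in place of methylamino on an aromatic carbon), comes out as a step that the two limits leave unreadable from compound 2 to compound 1, and the change of core, (thiophen-3-yl in place of thiophen-2-yl on an aromatic carbon), comes out as a step that the two limits leave unreadable from compound 2 to compound 3. Compound 4 `Cc1ncnc2c1c(-c1ccsc1)cn2[C@@H]1O[C@H](CO)[C@@H](O)[C@H]1O` has not been measured. It differs from compound 3 by methyl in place of methylamino on an aromatic carbon, the same change that carries compound 2 to compound 1. Given that compound 3 rests at the limit of > 20000 nM in this assay, at which 3 of the 3 values shown sit, and the earlier step reads a step that the two limits leave unreadable from compound 2 to compound 1, the step from compound 3 to compound 4 is expected to be a step that the limit leaves unreadable from compound 3 to compound 4. Compound 4 is therefore estimated at 40000 nM in this assay, with an expected range of 15000 nM to 150000 nM, most likely reported once more only as a limit.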

Compound 4, half-maximal inhibitory concentration: 1430 nM
The estimate for compound 4 lay 28-fold (1.45 log units) above the measured number, and the stated range ends above it.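

In this assay, methyl in place of methylamino gives an at least 13-fold lower number from compound 3 to compound 4 (1.14 log units; beyond the scatter), and with methyl held constant, thiophen-3-yl in place of thiophen-2-yl gives an at least 13-fold lower number from compound 1 to compound 4 (1.14 log units; beyond the scatter). The change therefore brings a readable number on the core of compound 4, but it does not do so on the thiophen-2-yl core, where compound 1 gives > 20000 nM, which is only a limit. The step between the two limited thiophen-2-yl compounds cannot be read, so the effect of the change on that core stays unknown, and both readable steps give only a minimum size: the limit of > 20000 nM in this assay, at which 3 of the 4 values shown sit.

The compounds shown leave open whether ethyl or a plain amino group in place of methyl would also give a readable number. Among these compounds, they also leave open whether methyl is the only such group that does so on this core.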